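Swapping the Aryl Group: From Compound 1 to Compound 3

This account rests on a few compounds, and the source may have more. Where it says the series, first, only, none or still open, it means among the compounds named here.

Compound 1 `CN(C)CCn1cnnc1-c1cc(Oc2ccc(NC(=O)N/N=C/c3ccc(O)c(Br)c3)cc2F)ccn1` gives 1860 nM in a functional assay on MKN-45 cells (Homo sapiens) for cytotoxicity, read by MTT assay, with a stated time of 72 h (a higher number here means a weaker inhibitor, a lower number a stronger inhibitor), the lowest of the two numbers measured. Compound 2 `CN(C)CCn1cnnc1-c1cc(Oc2ccc(NC(=O)N/N=C/c3cc(Br)c(O)c(Br)c3)cc2F)ccn1` gives 4320 nM, and the step of a 2.3-fold higher number from compound 1 to compound 2 (0.37 log units; beyond the scatter) corresponds to a bromo in place of hydrogen on an aromatic carbon. Compound 3 `CN(C)CCn1cnnc1-c1cc(Oc2ccc(NC(=O)N/N=C/c3ccc(Cl)cc3)cc2F)ccn1` is not yet measured; it differs from compound 1 by 4-chlorophenyl in place of 3-bromo-4-hydroxyphenyl on a carbon with a double bond to nitrogen. For the measured compounds named here, no measured step matches this change; the only one available, a 2.3-fold higher number from compound 1 to compound 2 (0.37 log units; beyond the scatter), was modest. A modest rise is therefore expected, a 1.6-fold higher number from compound 1 to compound 3 (0.21 log units; within the scatter), giving an estimated value for compound 3 of 3000 nM, within the range 1200 nM to 8000 nM.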

Compound 3, half-maximal inhibitory concentration: 570 nM
Compound 3: the middle estimate sits 5.3-fold (0.72 log units) above what was measured; the measured number lies below the stated range.
By their numbers in this assay, from the lowest: compound 3; then compound 1; then compound 2.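

In this assay, the aryl group on the carbon with a double bond to nitrogen can be replaced without losing activity: 4-chlorophenyl gives a 3.3-fold lower number from compound 1 to compound 3 (0.51 log units; beyond the scatter) and also a 7.6-fold lower number from compound 2 to compound 3 (0.88 log units; beyond the scatter) in place of the dibrominated group. In these compounds, then, the ring hydroxyl is not needed for a low number. Nothing shown bears on the reason for these steps. From the compounds shown here alone, the swap changes halogen and hydroxyl together, so the share of each stays unknown. Going by these compounds, a plain phenyl ring or a methoxy group in place of the chlorine remains open.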